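This account rests on a few compounds, and the source may have more. Where it says the series, first, only, none or still open, it means among the compounds named here.

Measured compounds in a functional assay on CHO cells for agonist activity at Free fatty acid receptor 1 (Homo sapiens), read by reporter gene assay; on this read-out lower numbers stand for smaller maximal responses and higher numbers for larger maximal responses:
- compound 1 `O=C(O)CCc1ccc(NCc2ccc(Cl)cc2)cc1` gives 111%
- compound 2 `O=C(O)CCc1ccc(NCc2ccc(-c3ccccc3)cc2)cc1` gives 111%
- compound 3 `O=C(O)CCCc1ccc(NCc2ccc(-c3ccccc3)cc2)cc1` gives 62%

Compound 1 stands level with compound 2 in this assay, and together these two give the highest numbers of the three. Between them lies no change at the digits printed from compound 1 to compound 2 (within the scatter), a change at the same end of the molecule where the new compound also differs. Among the compounds with values here, the only large step in the set is a number 49 percentage points lower from compound 2 to compound 3 (beyond the scatter), which comes from lengthening the acid-bearing chain, a part of the molecule that compound 4 leaves untouched.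

Compound 4 `O=C(O)CCc1ccc(NCc2ccc(Cl)c(Cl)c2)cc1` differs from compound 1 in one place: chloro in place of hydrogen on an aromatic carbon. Within the data shown here, the measured step that bears on this is the one from compound 1 to compound 2, where swapping the chloro for a phenyl on that aromatic carbon left the maximal response unchanged within the scatter. The chain step is not relevant to this change. Nothing in the data points to a move in either direction, so in this assay compound 4 is expected to show a number 3 percentage points lower from compound 1 to compound 4 (within the scatter), that is, no change beyond the scatter.

The estimate for compound 4 in this assay is 108%, expected to fall between 90% and 125%.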

Compound 4, largest response reached (reported as percent of maximum), in percent of the reference or control that the assay uses: 117%
Compound 4: the middle estimate sits 9 percentage points below what was measured; the measured number falls inside the stated range.
By their numbers in this assay, from the lowest: compound 3; then compounds 1, 2 and 4 (each within the scatter of the next).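

In this assay, chloro in place of hydrogen on the aromatic carbon ortho to a chloro group and meta to a large group gives a number 6 percentage points higher from compound 1 to compound 4 (within the scatter). Within the data shown here, the earlier step from compound 1 to compound 2 only exchanged the chloro already on this ring for a phenyl, whereas compound 4 keeps that chloro and fills a second aromatic carbon, so it is the first sign that this position can carry a chloro while the maximal response stays at the level of compound 1. No measurement at hand offers an explanation for this result.

The compounds shown leave open whether a group other than chloro at this position, such as methoxy, trifluoromethyl or an amine, would also keep the response at this level. They also leave open whether this second chloro would give the same result on the longer acid-bearing chain of compound 3, where the response is already lower, as a number 49 percentage points lower from compound 2 to compound 3 (beyond the scatter) shows.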